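The source may hold more compounds than are shown below. What is called first, only, known or untested is meant among the compounds shown, and "the series" means these compounds.

In a functional assay on the whole organism (strain CD1) with Mus musculus as the target, in the maximal electroshock model, with a stated time of 4 h (a higher number here means that more compound is needed for the effect, a lower number that less compound is needed), the measured compounds gave:

compound 1, `CC(C)C1(C(C)C)NC(=O)N(CN2CCN(c3ccccc3)CC2)C1=O`: 300 mg/kg
compound 2, `O=C1NC(c2ccccc2)(c2ccccc2)C(=O)N1CN1CCN(c2ccccc2)CC1`: 100 mg/kg
compound 3, `CN1CCN(CN2C(=O)NC(c3ccccc3)(c3ccccc3)C2=O)CC1`: 10 mg/kg

Compound 1 gives the highest number of the three; compound 2 needs less, and compound 3 less still, with the step of a 10-fold lower number from compound 2 to compound 3 (1.00 log units; beyond the scatter) set beyond the scatter.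

Compound 4, `CC(C)C1(C(C)C)NC(=O)N(CN2CCN(c3ccc(F)cc3)CC2)C1=O`, differs from compound 1 by fluoro in place of hydrogen on an aromatic carbon. Going by the values given here, the only measured step concerns methyl in place of phenyl on an amine nitrogen in a ring and does not touch this change, so no measured step bears on it. With nothing to point either way, the expected step is no change at the digits printed from compound 1 to compound 4 (within the scatter), that is, none beyond the scatter in this assay. Compound 4 is therefore estimated to give 300 mg/kg, with a range from 150 mg/kg to 600 mg/kg.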

Compound 4, minimum effective dose: 100 mg/kg
Beside the measured number, compound 4's estimate is 3.0-fold (0.48 log units) above it; measured number below the stated range.
By their numbers in this assay, from the lowest: compound 3; then compounds 2 and 4 (each within the scatter of the next); then compound 1.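

In this assay the change from phenyl to 4-fluorophenyl gives a 3.0-fold lower number from compound 1 to compound 4 (0.48 log units; beyond the scatter) on the core of compound 1. The earlier step replaced a whole phenyl with methyl, whereas this one keeps the phenyl and shows that a single fluoro on its ring is enough to move the number beyond the scatter. Nothing available explains why the number falls. As far as these compounds go, it remains open whether chloro or methoxy at this place would give a similar step, and whether fluoro would do the same on the phenyl of compound 2.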